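A few compounds are considered here, and "the series" means these few. Any claim that something is new, unique, unknown or untested is made for them only; others in the source may bear on it.

Working notes on the series. Three compounds have a number in a functional assay on MCF7 cells (Homo sapiens) for inhibition, read by MTT assay, with a stated time of 48 h; a higher number here means a weaker inhibitor, a lower number a stronger inhibitor. Compound 1 `CCOC(=O)C1=C(NN=C(C(C)=O)C(C)=O)Nc2[nH]nc(C)c2C1c1ccc(N(C)C)cc1` gives 9740 nM. Compound 2 `CCOC(=O)C1=C(N/C=N/c2ccc([N+](=O)[O-])cc2)Nc2[nH]nc(C)c2C1c1ccc(N(C)C)cc1` gives 58600 nM in this assay, and compound 3 `CCOC(=O)C1=C(N/C=N/c2ccc(C)cc2)Nc2[nH]nc(C)c2C1c1ccc(N(C)C)cc1` gives 50500 nM there. Compound 3 thus holds the second highest of the three numbers: its nearest neighbour is compound 2, with a 1.2-fold lower number from compound 2 to compound 3 (0.06 log units; within the scatter), and its furthest is compound 1, with a 5.2-fold higher number from compound 1 to compound 3 (0.71 log units; beyond the scatter).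

Compound 4 `CCOC(=O)C(=NNC1=C(C(=O)OCC)C(c2ccc(N(C)C)cc2)c2c(C)n[nH]c2N1)C(=O)OCC` is not yet measured. The change from compound 3 is a group of 12 heavy atoms (7 carbon, 1 nitrogen, 4 oxygen; no ring) in place of a group of 9 heavy atoms (8 carbon, 1 nitrogen; one six-membered aromatic ring of carbon only), on an amine nitrogen. Within the data shown here, two measured steps bear on it, both in the opposite sense: the replacement of the no-ring group of compound 1 by a ring-bearing group gave a 5.2-fold higher number from compound 1 to compound 3 (0.71 log units; beyond the scatter) and, with the other ring-bearing group, a 6.0-fold higher number from compound 1 to compound 2 (0.78 log units; beyond the scatter). Both steps were modest and beyond the scatter. Compound 4 returns to a no-ring group resembling the group of compound 1, so the number in this assay is expected to fall back toward the number of compound 1, and the step expected is a 4.2-fold lower number from compound 3 to compound 4 (0.62 log units; beyond the scatter), in the direction of a stronger inhibitor. The value of compound 4 in this assay is therefore estimated at 12000 nM, with a range of 5000 nM to 30000 nM.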

Compound 4, half-maximal inhibitory concentration: 89800 nM
For compound 4 the middle estimate is 7.5-fold (0.87 log units) below the measured one, outside the stated range (above it).
By their numbers in this assay, from the lowest: compound 1; then compounds 3, 2 and 4 (each within the scatter of the next).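

On an amine nitrogen, a no-ring group does not by itself bring the number back to that of compound 1: in this assay the exchange of one no-ring group for another gives a 9.2-fold higher number from compound 1 to compound 4 (0.96 log units; beyond the scatter) and so shows that the groups of this kind are not interchangeable. Compound 4 goes against the reading that the ring-bearing groups alone set compounds 2 and 3 apart from compound 1, since the steps to it, a 1.8-fold higher number from compound 3 to compound 4 (0.25 log units; within the scatter) and a 1.5-fold higher number from compound 2 to compound 4 (0.19 log units; within the scatter), leave it level with both, and a ring at this place therefore shows no readable effect in these two pairs. No measurement at hand accounts for the step between the two no-ring groups.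

Going by these compounds, what remains open is which part of the group entering in compound 4 goes with the step from compound 1, the ketone carbonyls of compound 1 or the ethyl esters of compound 4. A carboxylic acid or a primary amide in the same place on the amine nitrogen, or a group holding one ketone and one ester, would help to separate these.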